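Sulfonamide Aryl Swap: From Difluorophenyl to Methoxyphenyl

A few compounds are considered here, and "the series" means these few. Any claim that something is new, unique, unknown or untested is made for them only; others in the source may bear on it.

Compound 1 `Cc1ccc(NS(=O)(=O)c2ccc(N3CCNC3=O)cc2)cc1`: 610 nM
Compound 2 `O=C1NCCN1c1ccc(S(=O)(=O)Nc2ccc(F)c(F)c2)cc1`: 620 nM
Compound 3 `O=C1NCCN1c1ccc(S(=O)(=O)Nc2ccc3c(c2)CCC3)cc1`: 240 nM

In a functional assay on MCF7 cells (Homo sapiens) for antiproliferative activity, read by sulforhodamine B assay, with a stated time of 48 h (a higher number here means a weaker inhibitor, a lower number a stronger inhibitor), compound 2 gives 620 nM, the top of the three numbers shown, although compound 1 with 610 nM cannot be told apart from it; only compound 3 with 240 nM gives a clearly lower number.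

Compound 4 `COc1ccc(NS(=O)(=O)c2ccc(N3CCNC3=O)cc2)cc1` differs from compound 2 in one place: 4-methoxyphenyl in place of 3,4-difluorophenyl on a sulfonamide nitrogen. Within the data shown here, the one measured step that bears on this is a 1.0-fold higher number from compound 1 to compound 2 (0.01 log units; within the scatter), which shows that exchanging one substituted phenyl for another on this sulfonamide nitrogen left this assay unmoved. A similar outcome is therefore expected here: no step beyond the scatter, a 1.1-fold lower number from compound 2 to compound 4 (0.05 log units; within the scatter). Compound 4 is thus estimated at 550 nM, with a range from 250 nM to 1200 nM.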

Compound 4, half-maximal inhibitory concentration: > 1000 nM
Compound 4: a limit, no number; the forecaster's own chance of this, stated with the estimate: 3%; middle value at least 1.8-fold (0.25 log units) away from the limit.
By their numbers in this assay, from the lowest: compound 3; then compounds 1 and 2 (each within the scatter of the next). At a limit, above all of these: compound 4.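

In this assay compound 4 gives > 1000 nM, which is a limit and not a number: the limit of > 1000 nM in this assay, at which 1 of the 4 values shown sits.

Methoxy in place of methyl on an aromatic carbon gives an at least 1.6-fold higher number from compound 1 to compound 4 (0.21 log units; that floor lies within the scatter), and 4-methoxyphenyl in place of 3,4-difluorophenyl on a sulfonamide nitrogen gives an at least 1.6-fold higher number from compound 2 to compound 4 (0.20 log units; that floor lies within the scatter). The earlier exchange of substituted phenyls left the number unmoved, whereas these steps show only a floor, so this position can no longer be called indifferent to the exchange, nor shown to be sensitive to it.

From the compounds shown here alone, how far compound 4 truly lies from compound 1 and compound 2 stays open. So does how a hydroxy group or an amine on that aromatic carbon would read.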